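The compounds below may be only part of what the source reports. "The series", "measured", "known", "first", "only" and "open" are said of these compounds alone.

Measured so far:
Compound 1 `COc1ccc(Oc2nc(Nc3ccc(C#N)cc3)nc3ccccc23)cc1` gives 340000 nM in an ADME assay on MT4 cells (Homo sapiens) for cytotoxicity, read by MTT assay, with a stated time of 4 days; a lower number here means that less compound is tolerated, a higher number that more compound is tolerated.
Compound 2 `Cc1cccc(C)c1Oc1nc(Nc2ccc(C#N)cc2)nc2ccccc12` gives 35000 nM in this assay.
Compound 3 `N#Cc1ccc(Nc2nc(Oc3ccc(Cl)cc3)c3ccccc3n2)cc1` gives 198000 nM in this assay.

Among these three numbers compound 3 stands second highest: the gap to compound 1, a 1.7-fold lower number from compound 1 to compound 3 (0.23 log units; within the scatter), is within the scatter, while the gap to compound 2 is larger, a 5.7-fold higher number from compound 2 to compound 3 (0.75 log units; beyond the scatter), and lies beyond it.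

Compound 4 `N#Cc1ccc(Nc2nc(Oc3c(Cl)cc(Cl)cc3Cl)c3ccccc3n2)cc1` has not yet been measured in this assay. It differs from compound 3 in one place: 2,4,6-trichlorophenyl in place of 4-chlorophenyl on an oxygen on an aromatic ring. Two of the measured steps bear on this change, since both swap the ring that sits on that oxygen. Going from a ring with one group at its far end to a ring carrying two groups flanking the oxygen gave a 9.7-fold lower number from compound 1 to compound 2 (0.99 log units; beyond the scatter), and the reverse kind of swap gave a 5.7-fold higher number from compound 2 to compound 3 (0.75 log units; beyond the scatter). Both point the same way: a ring bearing groups on both sides of the oxygen went with a lower number, meaning less compound was tolerated. The 2,4,6-trichlorophenyl of compound 4 carries such flanking groups together with one at the far end.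

Compound 4 is therefore expected to give a lower number than compound 3, a step of about a 4.4-fold lower number from compound 3 to compound 4 (0.64 log units; beyond the scatter), with the estimate for compound 4 in this assay being 45000 nM, in a range from 12000 nM to 170000 nM.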

Compound 4, half-maximal cytotoxic concentration: 56000 nM
Compound 4: the middle estimate sits 1.2-fold (0.09 log units) below what was measured, and the stated range covers the measured number.
By their numbers in this assay, from the lowest: compounds 2 and 4 (each within the scatter of the next); then compounds 3 and 1 (each within the scatter of the next).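

In this assay, the change from 4-chlorophenyl to 2,4,6-trichlorophenyl on this oxygen brought a 3.5-fold lower number from compound 3 to compound 4 (0.55 log units; beyond the scatter), so a lower number at this place is not tied to the methyl groups of 2,6-dimethylphenyl and also appears with a ring carrying only chlorine as its added groups. The two rings cannot be told apart in this assay, with a 1.6-fold higher number from compound 2 to compound 4 (0.20 log units; within the scatter), whereas the change from 4-methoxyphenyl to 2,4,6-trichlorophenyl gives a clear difference, with a 6.1-fold lower number from compound 1 to compound 4 (0.78 log units; beyond the scatter). Nothing at hand explains why these ring changes shift the number.

As far as these compounds go, compound 4 gains two chlorines at once, so it remains open whether both are needed for the step from compound 3 or one alone would do, a question that a ring such as 2,6-dichlorophenyl could help to settle. It also remains open how this place would respond to groups of another kind, such as a ring bearing an amine or a carboxylic acid, since every ring shown here carries only methyl, methoxy or chloro groups.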